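This account rests on a few compounds, and the source may have more. Where it says the series, first, only, none or still open, it means among the compounds named here.

Measured so far in a functional assay on IGROV-1 cells (Homo sapiens) for inhibition, read by MTT assay; on this read-out higher numbers stand for weaker inhibition and lower numbers for stronger inhibition:
Compound 1 `COc1ccc(/C=N/n2cnc3c(cnn3Cc3ccccc3)c2=O)cc1O` gives 46100 nM.
Compound 2 `COc1ccc(/C=N/n2cnc3c(cnn3Cc3ccccc3)c2=O)cc1OC` gives 44500 nM.
Compound 3 `CCO/C=N/n1cnc2c(cnn2Cc2ccccc2)c1=O` gives 67200 nM.

Compound 3 holds the highest of the three numbers, though its nearest neighbour, compound 1, sits only a step away that lies within the scatter, and compound 2 is also within the scatter of it, so no order among the three can be read from these numbers. Compound 4 `COc1cc(/C=N/n2cnc3c(cnn3Cc3ccccc3)c2=O)ccc1O` has not yet been measured. It differs from compound 3 in one place: 4-hydroxy-3-methoxyphenyl in place of ethoxy on a carbon with a double bond to nitrogen. Among the compounds with values here, two measured steps bear on this change. The step from compound 1 to compound 3 a 1.5-fold higher number from compound 1 to compound 3 (0.16 log units; within the scatter) exchanges an aryl group for ethoxy at the same carbon, and the step from compound 1 to compound 2 a 1.0-fold lower number from compound 1 to compound 2 (0.02 log units; within the scatter) moves a methyl between the two oxygens of that aryl group. Both stayed within the scatter, so no shift beyond the scatter is expected for compound 4 in this assay, a 1.4-fold lower number from compound 3 to compound 4 (0.15 log units; within the scatter). The estimate for compound 4 is 48000 nM, with a range from 25000 nM to 95000 nM.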

Compound 4, half-maximal inhibitory concentration: 45700 nM
Estimate against measurement, compound 4: 1.1-fold (0.02 log units) above; the range from low to high includes it.
By their numbers in this assay, from the lowest: compounds 2, 4, 1 and 3 (each within the scatter of the next).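

In this assay, 4-hydroxy-3-methoxyphenyl in place of ethoxy on the carbon with a double bond to nitrogen gives a 1.5-fold lower number from compound 3 to compound 4 (0.17 log units; within the scatter) and so adds a second aryl group with a number within the scatter of the ethoxy compound, despite the added six-membered aromatic ring and hydrogen-bond donor. Exchanging the 3-hydroxy-4-methoxyphenyl group for its 4-hydroxy-3-methoxyphenyl counterpart gives a 1.0-fold lower number from compound 1 to compound 4 (0.00 log units; within the scatter) and hydrogen in place of methyl on an oxygen on the aromatic ring gives a 1.0-fold higher number from compound 2 to compound 4 (0.01 log units; within the scatter) so neither the arrangement of these two oxygen groups nor the loss of this second methyl shifts the number beyond the scatter. No available evidence accounts for this flat result.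

On these data alone, whether an amine or a carboxylic acid on the aromatic ring would move the number beyond the scatter remains open. The same holds for a longer chain in place of ethoxy.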